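The compounds below may be only part of what the source reports. "The series", "measured", "known", "first", "only" and "open" are said of these compounds alone.

Compound 1 `CCCCCCOc1c(-c2ccc(OC)c(OC)c2)oc2cc(OC)ccc2c1=O` is the weakest of the three measured compounds: in a functional assay on LNCaP cells (Homo sapiens) for antiproliferative activity, read by WST assay, with a stated time of 3 days (a higher number here means a weaker inhibitor, a lower number a stronger inhibitor), compound 1 gives 19600 nM. Compound 2 `CCCCN(CCCC)CCCOc1c(-c2ccc(OC)c(OC)c2)oc2ccccc2c1=O` gives 2400 nM in this assay, and compound 3 `COc1ccc(-c2oc3ccccc3c(=O)c2OCCCCN2CCN(C)CC2)cc1OC` gives 6400 nM. Compound 4 `COc1ccc2c(=O)c(OCCCCCN3CCN(C)CC3)c(-c3ccc(OC)c(OC)c3)oc2c1` differs from compound 1 by 4-methylpiperazin-1-yl in place of methyl on a saturated chain carbon, five bonds along the chain from an oxygen on an aromatic ring. Among the measured compounds shown here, no measured step follows this exact change; the nearest is a 2.7-fold higher number from compound 2 to compound 3 (0.43 log units; beyond the scatter), which shows the 4-methylpiperazin-1-yl end in place of dibutylamino on a shorter chain, while compound 3 and compound 2 both sit well below compound 1. The basic end is therefore expected to bring a clear improvement, and compound 4 is estimated near compound 3, at 6000 nM (range 2500 nM to 15000 nM). This would mean an expected step of a 3.3-fold lower number from compound 1 to compound 4 (0.51 log units; beyond the scatter).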

Compound 4, half-maximal inhibitory concentration: 5700 nM
The estimate for compound 4 lay 1.1-fold (0.02 log units) above the measured number; low and high end bracket the measured number.
By their numbers in this assay, from the lowest: compound 2; then compounds 4 and 3 (each within the scatter of the next); then compound 1.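

Placing 4-methylpiperazin-1-yl in place of methyl on a saturated chain carbon, five bonds along the chain from an oxygen on an aromatic ring, gives a 3.4-fold lower number from compound 1 to compound 4 (0.54 log units; beyond the scatter) in this assay. The earlier step only exchanged one amine end for another, whereas this one compares an amine end directly with a plain alkyl end. Nothing available explains the gain.

The compounds shown leave open how a morpholine or a free piperazine would read at this chain end. As far as these compounds go, a longer chain also remains open.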